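The source may hold more compounds than are shown below. What is called first, only, known or untested is meant among the compounds shown, and "the series" means these compounds.

Compound 1 `C/C=C/C(=O)Nc1cccc(Cn2nc(-c3ccc(Oc4ccccc4)cc3)cc2CO)c1` and compound 2 `C=CC(=O)Nc1cccc(Cn2nc(-c3ccc(Oc4ccccc4)cc3)cc2CO)c1` share a core and differ only at one end of the molecule: vinyl in place of prop-1-en-1-yl on a carbonyl carbon. In a functional assay on Z-138 cells (Homo sapiens) for inhibition, read by luminescence and CellTiter-Glo, with a stated time of 72 h (a lower number here means a stronger inhibitor, a higher number a weaker inhibitor), compound 1 gives 5700 nM, and compound 2 gives 6000 nM. That change made a 1.1-fold higher number from compound 1 to compound 2 (0.02 log units; within the scatter), so the two compounds cannot be told apart here.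

Compound 3 `C/C=C/C(=O)N1CCCC(n2nc(-c3ccc(Oc4ccccc4)cc3)cc2CO)C1` is built on a different core; how the two cores differ is not broken down here. In this assay compound 3 gives 51100 nM, the highest of the three numbers, and its gap to compound 2 and to compound 1 lies beyond the scatter.

Compound 4 `C=CC(=O)N1CCCC(n2nc(-c3ccc(Oc4ccccc4)cc3)cc2CO)C1` is not yet measured. It relates to compound 3 as compound 2 relates to compound 1: vinyl in place of prop-1-en-1-yl on a carbonyl carbon. The place is not the same word for word, since here the carbonyl carbon's other neighbour is an amide-type nitrogen in a ring rather than an amide-type nitrogen, so this is the same kind of change, not the same change. Because the earlier step was a 1.1-fold higher number from compound 1 to compound 2 (0.02 log units; within the scatter), the step from compound 3 to compound 4 is expected to be small, about a 1.1-fold higher number from compound 3 to compound 4 (0.03 log units; within the scatter). The estimate for compound 4 in this assay is 55000 nM, expected to fall between 25000 nM and 120000 nM.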

Compound 4, half-maximal inhibitory concentration: 14600 nM
For compound 4 the middle estimate is 3.8-fold (0.58 log units) above the measured one; the measured number lies below the stated range.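

In this assay, the swap of prop-1-en-1-yl for vinyl on a carbonyl carbon did not behave the same way on the two cores: the same change on two cores in this assay, a 1.1-fold higher number (0.02 log units; within the scatter) from compound 1 to compound 2 and a 3.5-fold lower number (0.54 log units; beyond the scatter) from compound 3 to compound 4, 3.7-fold (0.57 log units) apart, beyond the scatter of two such steps. On the core of compound 3 the change gives a 3.5-fold lower number from compound 3 to compound 4 (0.54 log units; beyond the scatter), whereas on the core of compound 1 it has no effect that can be told apart from the scatter, so the size of this step cannot simply be carried from one core to the other. This rests on a single pair of compounds per core in one cell assay, and it does not show why the two steps differ or how the change would behave on any further core.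

The compounds shown leave open how other groups on the same carbonyl carbon would behave on these two cores, such as a longer chain or a chain carrying an amine. They also leave open whether the hydroxymethyl group on the shared part of the molecule could be replaced, for example by a carboxylic acid.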